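Cytotoxicity notes: changing the benzyl substituent of compound 1

The source may hold more compounds than are shown below. What is called first, only, known or untested is meant among the compounds shown, and "the series" means these compounds.

Measured so far:
compound 1, `Cc1cc(/C=C2\SC(=S)N(Cc3ccc(C(F)(F)F)cc3)C2=O)c(C)n1-c1ccc(O)c(C(=O)O)c1` — 45900 nM
compound 2, `Cc1cc(/C=C2\SC(=S)N(Cc3ccc(C(C)(C)C)cc3)C2=O)c(C)n1-c1ccc(O)c(C(=O)O)c1` — 55200 nM

In an ADME assay on MT2 cells (Homo sapiens) for cytotoxicity, read by XTT assay, with a stated time of 4 days (on this read-out lower numbers stand for higher toxicity in this test and higher numbers for lower toxicity in this test), compound 1 gives the lowest of the two numbers, with compound 2 within the scatter of it: a 1.2-fold higher number from compound 1 to compound 2 (0.08 log units; within the scatter). Compound 3, `COc1cccc(CN2C(=O)/C(=C/c3cc(C)n(-c4ccc(O)c(C(=O)O)c4)c3C)SC2=S)c1`, differs from compound 1 by 3-methoxyphenyl in place of 4-(trifluoromethyl)phenyl on a saturated chain carbon bound to an amide-type nitrogen in a ring. For the measured compounds named here, only the step from compound 1 to compound 2, which alters the same benzyl group, bears on this change, and it stayed within the scatter. For compound 3 no step beyond the scatter is therefore expected in this assay. Compound 3 is estimated at 50000 nM, range 25000 nM to 100000 nM. This estimate means a 1.1-fold higher number from compound 1 to compound 3 (0.04 log units; within the scatter).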

Compound 3, half-maximal cytotoxic concentration: 102000 nM
The estimate for compound 3 lay 2.0-fold (0.31 log units) below the measured number, outside the stated range (above it).
By their numbers in this assay, from the lowest: compounds 1, 2 and 3 (each within the scatter of the next, the first and the last beyond it).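

A change at this benzyl group now gives a 2.2-fold higher number from compound 1 to compound 3 (0.35 log units; beyond the scatter) in this assay and, unlike the step between the two earlier compounds, passes beyond the scatter. For the compounds shown here, the change from the tert-butyl group gives a 1.8-fold higher number from compound 2 to compound 3 (0.27 log units; within the scatter) and stays within the scatter, so only the comparison with the trifluoromethyl group separates compound 3 from the earlier compounds. Nothing available accounts for either step. Still open, on these data alone, is how a benzyl group carrying an amine or a carboxylic acid would read in this assay. Also open, as far as these compounds go, is whether 4-methoxybenzyl would read like 3-methoxybenzyl.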